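A few compounds are considered here, and "the series" means these few. Any claim that something is new, unique, unknown or untested is made for them only; others in the source may bear on it.

Measured compounds and their values:

Compound 1, `COc1cc(C(=O)C2Sc3nnc(-c4cc(OC)c(OC)c(OC)c4)n3NC2c2ccco2)cc(OC)c1OC`: > 100000 nM
Compound 2, `COc1cc(-c2nnc3n2NC(c2ccco2)C(C(=O)c2ccc(Br)cc2)S3)cc(OC)c1OC`: > 100000 nM
Compound 3, `COc1cc(-c2nnc3n2NC(c2ccco2)C(C(=O)c2ccccc2)S3)cc(OC)c1OC`: 90900 nM

In a functional assay on HepG2 cells (Homo sapiens) for cytotoxicity, read by MTT assay, with a stated time of 48 h (a higher number here means a weaker inhibitor, a lower number a stronger inhibitor), compound 1 reaches only a limit of the assay, > 100000 nM. Compound 2 likewise reaches only a limit, > 100000 nM. Going by the values given here, compound 3 is the one compound of the three for which this assay returns a number, 90900 nM. The readable steps are small: an at least 1.1-fold lower number from compound 1 to compound 3 (0.04 log units; that floor lies within the scatter), and an at least 1.1-fold lower number from compound 2 to compound 3 (0.04 log units; that floor lies within the scatter). The step between the two limits, a step that the two limits leave unreadable from compound 1 to compound 2, cannot be sized. Two of the three values sit at the limit of > 100000 nM in this assay, at which 2 of the 3 values shown sit.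

Compound 4, `COc1cc(-c2nnc3n2NC(c2ccco2)C(C(=O)c2ccc(C)cc2)S3)cc(OC)c1OC`, differs from compound 3 in one place: methyl in place of hydrogen on an aromatic carbon. The step from compound 2 to compound 3, hydrogen in place of bromo on an aromatic carbon, is the nearest comparison, and its floor lies within the scatter. Among the compounds with values here, nothing among the measured steps therefore points to a change beyond the scatter, and the weight of values at the limit suggests compound 4 may itself return only a limit. Compound 4 is expected to give about 100000 nM in this assay, between 45000 nM and 200000 nM, an estimated step of a 1.1-fold higher number from compound 3 to compound 4 (0.04 log units; within the scatter).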

Compound 4, half-maximal inhibitory concentration: 17400 nM
The estimate for compound 4 lay 5.7-fold (0.76 log units) above the measured number; the whole stated range lies above it.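

In this assay, going by these compounds alone, the result shows that the aromatic carbon para to a large group is a place where a single added methyl can matter: methyl in place of hydrogen gives a 5.2-fold lower number from compound 3 to compound 4 (0.72 log units; beyond the scatter), whereas no earlier readable step went beyond the scatter. The same compound also stands apart from its bromo counterpart, with an at least 5.7-fold lower number from compound 2 to compound 4 (0.75 log units; beyond the scatter), and 4-methylphenyl stands apart from 3,4,5-trimethoxyphenyl on the carbonyl carbon, with an at least 5.7-fold lower number from compound 1 to compound 4 (0.75 log units; beyond the scatter). Those two steps are only floors, since compound 1 and compound 2 each reach only a limit of the assay: the limit of > 100000 nM in this assay, at which 2 of the 4 values shown sit.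

With only hydrogen, bromo and methyl compared at this carbon, the compounds shown leave open whether the lower number is particular to methyl or would also appear with an ethyl group, a longer chain or an amine. They also leave open how far the true values of compound 1 and compound 2 lie from their limit, and so how large the steps to compound 4 really are.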